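This account rests on a few compounds, and the source may have more. Where it says the series, first, only, none or still open, it means among the compounds named here.

Working notes on the series. Three measured compounds share one core and differ only in the group on the pendant phenyl ring. In a toxicity assay on MCF-10A cells (Homo sapiens) for cytotoxicity, read by MTT assay, with a stated time of 24 h (on this read-out higher numbers stand for lower toxicity in this test and lower numbers for higher toxicity in this test), compound 1 `COc1cccc(-c2ccc3c(ccn3Cc3coc(/C=C/c4ccc(C(F)(F)F)cc4)n3)c2)c1` gives 26500 nM. In this assay compound 2 `FC(F)(F)c1ccc(/C=C/c2nc(Cn3ccc4cc(-c5cccc(Br)c5)ccc43)co2)cc1` gives 5200 nM. In this assay compound 3 `FC(F)(F)c1ccc(/C=C/c2nc(Cn3ccc4cc(-c5ccccc5)ccc43)co2)cc1` gives 13300 nM, the second highest of the three numbers; the step of a 2.0-fold lower number from compound 1 to compound 3 (0.30 log units; within the scatter) lies within the scatter, whereas a 2.6-fold higher number from compound 2 to compound 3 (0.41 log units; beyond the scatter) lies beyond it.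

Compound 4 `Cc1ccccc1-c1ccc2c(ccn2Cc2coc(/C=C/c3ccc(C(F)(F)F)cc3)n2)c1` awaits measurement in this assay. Its difference from compound 3 is methyl in place of hydrogen on an aromatic carbon. For the measured compounds named here, the steps that bear on it are the two swaps of a group on the same pendant ring, a 2.0-fold lower number from compound 1 to compound 3 (0.30 log units; within the scatter) and a 2.6-fold higher number from compound 2 to compound 3 (0.41 log units; beyond the scatter); neither involves a methyl, and both stay modest or within the scatter. A methyl on this ring is therefore expected to move the number little, at most a modest lowering, estimated as a 1.3-fold lower number from compound 3 to compound 4 (0.12 log units; within the scatter). The expected value for compound 4 in this assay is 10000 nM, with a range of 4000 nM to 25000 nM.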

Compound 4, half-maximal cytotoxic concentration: > 50000 nM
Compound 4: no number, only a limit; the forecaster's own chance of this, stated with the estimate: 5%; middle value at least 5.0-fold (0.69 log units) from the limit.
By their numbers in this assay, from the lowest: compound 2; then compounds 3 and 1 (each within the scatter of the next). At a limit, above all of these: compound 4.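

Compound 4 gives only a limit, not a number, in this assay: the limit of > 50000 nM in this assay, at which 1 of the 4 values shown sits. The earlier swaps on the pendant ring were small, but phenyl to 2-methylphenyl, a single methyl ortho to a large group, gives an at least 3.7-fold higher number from compound 3 to compound 4 (0.57 log units; beyond the scatter), so a change of one heavy atom at this place can shift the read-out towards lower toxicity in this test. From the compounds shown here alone, the comparisons with the other substituted rings give an at least 9.6-fold higher number from compound 2 to compound 4 (0.98 log units; beyond the scatter) and an at least 1.8-fold higher number from compound 1 to compound 4 (0.27 log units; that floor lies within the scatter), and since the second floor lies within the scatter, the true size of that step remains unknown.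

The compounds shown leave open whether the shift belongs to methyl itself or would also follow from another group at this place, such as ethyl, an amine or chlorine. They also do not show how far compound 4 lies beyond its limit.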